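This account rests on a few compounds, and the source may have more. Where it says the series, first, only, none or still open, it means among the compounds named here.

Compound 1 `FC(F)(F)Oc1cccc(Nc2nnnc3ccc(N4CCC(N5CCCCC5)CC4)nc23)c1`: 4900 nM
Compound 2 `CC(C)(C)OC(=O)N1CCC(CNc2ccc3nnnc(Nc4cccc(OC(F)(F)F)c4)c3n2)CC1`: > 100000 nM
Compound 3 `CC(C)N1CCN(c2ccc3nnnc(Nc4cccc(OC(F)(F)F)c4)c3n2)CC1`: 10700 nM

All three compounds were tested in a functional assay on LNCaP cells (Homo sapiens) for antiproliferative activity, read by MTT assay, with a stated time of 96 h; on this read-out lower numbers stand for stronger inhibition and higher numbers for weaker inhibition. Compound 1, at 4900 nM, holds the lower of the two true numbers, and compound 3, at 10700 nM, lies above it by a gap beyond the usual scatter. Compound 2 gives > 100000 nM, which is a limit of the assay and not a number.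

The next compound to be measured is compound 4 `FC(F)(F)Oc1cccc(Nc2nnnc3ccc(N4CCC(N5CCCC5)CC4)nc23)c1`. It keeps the core of compound 1 but has pyrrolidin-1-yl in place of piperidin-1-yl on a saturated ring carbon. No measured pair among these compounds shows a change of this kind, so the expectation rests on compound 1 at 4900 nM, and no step beyond the scatter is expected in this assay. The estimated change is a 1.0-fold higher number from compound 1 to compound 4 (0.01 log units; within the scatter). For compound 4 the expected value is 5000 nM, with an estimated range from 2000 nM to 13000 nM.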

Compound 4, half-maximal inhibitory concentration: 10700 nM
The estimate for compound 4 lay 2.1-fold (0.33 log units) below the measured number, within the range that was stated.
By their numbers in this assay, from the lowest: compound 1; then compounds 3 and 4 (each within the scatter of the next). At a limit, above all of these: compound 2.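

In this assay the saturated ring carbon of compound 1 proves modestly sensitive to the ring it carries: a five-membered pyrrolidin-1-yl in place of the six-membered piperidin-1-yl gives a 2.2-fold higher number from compound 1 to compound 4 (0.34 log units; beyond the scatter), the first step read at this position. Changing the whole side group, with 4-(pyrrolidin-1-yl)piperidin-1-yl in place of 4-isopropylpiperazin-1-yl on an aromatic carbon, gives no change at the digits printed from compound 3 to compound 4 (within the scatter), so these two side groups cannot be told apart in this assay. Nothing measured here offers a reason for the step from the piperidin-1-yl to the pyrrolidin-1-yl ring.

Going by these compounds, it remains open whether a larger azepan-1-yl ring on the same carbon would give a lower number than compound 1 at 4900 nM. Also open, on these data alone, is how an open-chain dimethylamino group or a morpholin-4-yl ring would compare there.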